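Swapping Hydroxy for Chloro on the Aryl Ring

The compounds below may be only part of what the source reports. "The series", "measured", "known", "first", "only" and "open" are said of these compounds alone.

Two thiosemicarbazones built on one shared core have been measured in a functional assay on PCO3 cells (Homo sapiens) for cytotoxicity, read by sulforhodamine B assay; on this read-out lower numbers stand for stronger inhibition of growth and higher numbers for weaker inhibition of growth. Compound 1 `CC1=CC[C@@H]([C@@](C)(O)CCCC(C)(C)NC(=S)N/N=C\c2ccc(O)cc2)CC1` gives 13900 nM, the lowest of the two numbers. Compound 2 `CC1=CC[C@@H]([C@@](C)(O)CCCC(C)(C)NC(=S)N/N=C\c2cccc(Cl)c2)CC1` gives 37800 nM; the step of a 2.7-fold higher number from compound 1 to compound 2 (0.43 log units; beyond the scatter), 3-chlorophenyl in place of 4-hydroxyphenyl on a carbon with a double bond to nitrogen, is modest but beyond the scatter. Compound 3 `CC1=CC[C@@H]([C@@](C)(O)CCCC(C)(C)NC(=S)N/N=C\c2ccc(Cl)cc2)CC1` has not yet been measured in this assay. It differs from compound 1 in one place: chloro in place of hydroxy on an aromatic carbon. Within the data shown here, the only step that bears on it is the one from compound 1 to compound 2, which also replaced the hydroxy-bearing ring with a chloro-bearing one and raised the number. For compound 3 a step of similar size and direction, a 2.2-fold higher number from compound 1 to compound 3 (0.33 log units; beyond the scatter), is therefore expected. Compound 3 is estimated to give 30000 nM, within 12000 nM to 75000 nM.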

Compound 3, concentration for total growth inhibition: 22700 nM
The estimate for compound 3 lay 1.3-fold (0.12 log units) above the measured number, and the stated range covers the measured number.
By their numbers in this assay, from the lowest: compounds 1, 3 and 2 (each within the scatter of the next, the first and the last beyond it).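

In this assay, chloro in place of hydroxy on this aromatic carbon, para to a large group, with nothing else altered, leaves compound 1 and compound 3 within the scatter of each other (a 1.6-fold higher number from compound 1 to compound 3 (0.21 log units; within the scatter)). Moving the chloro also leaves two compounds within the scatter of each other (a 1.7-fold lower number from compound 2 to compound 3 (0.22 log units; within the scatter)). Only compound 1 and compound 2, which differ in both the group and its place on the ring, lie beyond the scatter of each other, so neither single change reaches that size here.

No available evidence accounts for these numbers. On these data alone, whether an amine, a methoxy group or a carboxylic acid at this position would give a number beyond the scatter of compound 1 remains open.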